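A few compounds are considered here, and "the series" means these few. Any claim that something is new, unique, unknown or untested is made for them only; others in the source may bear on it.

Three measured compounds share one core and differ only in the group on the aromatic nitrogen. In a functional assay on CHO cells for antagonist activity at sphingosine 1-phosphate receptor 2 (Homo sapiens), read by GTPgammaS binding (on this read-out lower numbers stand for stronger inhibition and higher numbers for weaker inhibition), compound 1 `CCn1nc(CC(=O)Nc2ccc(OC(F)(F)F)c(Cl)c2)c2ccccc2c1=O` gives 473 nM, and compound 2 `O=C(O)Cn1nc(CC(=O)Nc2ccc(OC(F)(F)F)c(Cl)c2)c2ccccc2c1=O` gives 754 nM. Compound 3 `O=C(Cc1nn(C2CCNC2)c(=O)c2ccccc12)Nc1ccc(OC(F)(F)F)c(Cl)c1` gives 42 nM in this assay, the lowest of the three numbers. Compound 4 `O=C(Cc1nn(C2CC2)c(=O)c2ccccc12)Nc1ccc(OC(F)(F)F)c(Cl)c1` has not been measured; its change from compound 3 is cyclopropyl in place of pyrrolidin-3-yl on an aromatic nitrogen. The measured steps that bear on it are an 11-fold lower number from compound 1 to compound 3 (1.05 log units; beyond the scatter) and an 18-fold lower number from compound 2 to compound 3 (1.25 log units; beyond the scatter): each time pyrrolidin-3-yl entered, the number fell by a large amount. Going the other way, to a group with no ring nitrogen, no hydrogen-bond donor and no acceptor, a rise in the number is expected. Compound 4 is expected to give about 350 nM in this assay, within a range from 100 nM to 1200 nM. This amounts to an expected step of an 8.3-fold higher number from compound 3 to compound 4 (0.92 log units; beyond the scatter).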

Compound 4, half-maximal inhibitory concentration: 565 nM
Compound 4: the middle estimate sits 1.6-fold (0.21 log units) below what was measured; measured number inside the range.
By their numbers in this assay, from the lowest: compound 3; then compounds 1, 4 and 2 (each within the scatter of the next).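

Swapping pyrrolidin-3-yl for cyclopropyl gives a 13-fold higher number from compound 3 to compound 4 (1.13 log units; beyond the scatter) in this assay, so having just any ring on the aromatic nitrogen does not secure the low number of compound 3. Cyclopropyl also stays level with the open-chain groups, with a 1.2-fold higher number from compound 1 to compound 4 (0.08 log units; within the scatter) and a 1.3-fold lower number from compound 2 to compound 4 (0.13 log units; within the scatter), which leaves pyrrolidin-3-yl alone standing apart among these four groups.

Nothing measured here gives a reason for this. Cyclopentyl, which has carbon in place of the ring nitrogen, and an open-chain amine such as 2-aminoethyl would help show whether the ring, the amine or both matter.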